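The source may report more compounds than this note shows. Statements on the series, on what has been measured and on what is new or still open speak of the compounds shown alone.

Measured so far:
compound 1, `Cc1cccc(NC(=O)CN2CCC(c3ccc(O)cc3)CC2)c1`, 60%
compound 2, `Oc1ccc(N2CCN(Cc3nc4ccccc4[nH]3)CC2)nc1`, 70%
compound 3, `O=C(CN1CCC(c2cccc[n+]2[O-])CC1)Nc1cccc(-c2ccccc2)c1`, 75%

In a functional assay on HEK293 cells for agonist activity at D(4) dopamine receptor (Homo sapiens), read by FLIPR (a higher number here means a larger maximal response, a lower number a smaller maximal response), compound 1 gives 60%, the lowest of the three numbers shown. Compound 2 lies within the usual scatter of compound 1, so the two cannot be ordered; compound 3 lies beyond it, the larger of the two gaps.

Compound 4 is `Cc1cccc(NC(=O)CN2CCC(c3ccccc3C)CC2)c1`. It differs from compound 1 in one place: 2-methylphenyl in place of 4-hydroxyphenyl on a saturated ring carbon. Within the data shown here, no pair of measured compounds isolates this change, so no measured step can be read across. The expected step from compound 1 to compound 4 is a number 8 percentage points lower from compound 1 to compound 4 (within the scatter), a small one, not clearly beyond the scatter, and downward rather than upward. Compound 4 is therefore expected to give about 52%, within 30% to 78%.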

Compound 4, largest response reached (reported as efficacy), in percent of the reference or control that the assay uses: 43%
The estimate for compound 4 lay 9 percentage points above the measured number; low and high end bracket the measured number.
By their numbers in this assay, from the lowest: compound 4; then compounds 1, 2 and 3 (each within the scatter of the next, the first and the last beyond it).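

In this assay, among these compounds, 2-methylphenyl in place of 4-hydroxyphenyl on the saturated ring carbon gives a number 17 percentage points lower from compound 1 to compound 4 (beyond the scatter), the first readable step at this position. The maximal response therefore responds to this exchange, yet it does not vanish: compound 4 still gives 43%. Nothing measured here bears on the reason for the step.

As far as these compounds go, the exchange removes the hydroxyl and adds the methyl together, so the share of each remains open. Unsubstituted phenyl, 4-methylphenyl or 2-hydroxyphenyl on the same carbon would separate the two.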